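The source may report more compounds than this note shows. Statements on the series, on what has been measured and on what is new or still open speak of the compounds shown alone.

Measured so far in an assay on L cells for inhibition of Protein-serine O-palmitoleoyltransferase porcupine (Mus musculus), read by reporter gene assay, with a stated time of 24 h; a higher number here means that more compound is needed for the effect, a lower number that less compound is needed:
Compound 1 `COc1ccc2nc(NC(=O)CNC(=O)c3nn(-c4ccccc4OC)c(=O)c4ccccc34)sc2c1`, compound 1 gives 90 nM.
Compound 2 `COc1ccc(-n2nc(C(=O)NCC(=O)Nc3nc4ccccc4s3)c3ccccc3c2=O)cc1`, compound 2 gives 25000 nM.
Compound 3 `COc1ccc(-n2nc(C(=O)NCC(=O)Nc3nc4ccc(Cl)cc4s3)c3ccccc3c2=O)cc1`, compound 3 gives 15 nM.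

Compound 3 has the lowest number of the three; compound 1 is nearest and compound 2 is furthest. Compound 4 `COc1ccc(-n2nc(C(=O)NCC(=O)Nc3nc4ccc(OC)cc4s3)c3ccccc3c2=O)cc1` differs from compound 3 in one place: methoxy in place of chloro on an aromatic carbon. Within the data shown here, the one step that bears on this position is a 1700-fold lower number from compound 2 to compound 3 (3.22 log units; beyond the scatter), which shows that a group there matters greatly. Compound 1 also carries methoxy at that position, yet differs elsewhere too, so its value only hints. In this assay compound 4 is therefore expected to move modestly toward a higher number, a 4.0-fold higher number from compound 3 to compound 4 (0.60 log units; beyond the scatter), giving an estimate of 60 nM with a range from 15 nM to 300 nM.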

Compound 4, half-maximal effective concentration: 60 nM
For compound 4 middle estimate and measured number coincide at the digits printed; the range from low to high includes it.
By their numbers in this assay, from the lowest: compound 3; then compounds 4 and 1 (each within the scatter of the next); then compound 2.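

Chloro is not the only group that works at this position: in this assay methoxy also brings a large change from hydrogen, with a 420-fold lower number from compound 2 to compound 4 (2.62 log units; beyond the scatter) as the step. Replacing chloro with methoxy gives up only a small part of that change, as a 4.0-fold higher number from compound 3 to compound 4 (0.60 log units; beyond the scatter) shows. With methoxy at this position, moving the other methoxy on the aromatic nitrogen's ring gives a 1.5-fold lower number from compound 1 to compound 4 (0.18 log units; within the scatter) and stays within the scatter.

Nothing available explains why a group here matters so much. Going by these compounds, how an amine, a carboxylic acid or a longer chain would behave at this position remains open.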